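Replacing a nitro group by fluoro in compound 1

This account rests on a few compounds, and the source may have more. Where it says the series, first, only, none or still open, it means among the compounds named here.

Going by the values given here, in a functional assay on CCRF-CEM cells (Homo sapiens) for cytotoxicity, in the absence of a further agent (a lower number here means a stronger inhibitor, a higher number a weaker inhibitor), compound 1 (`Nc1nc(N)c(CCCN(Cc2ccc(NC(CCC(=O)O)C(=O)O)cc2)c2cc(F)c([N+](=O)[O-])cc2[N+](=O)[O-])c(O)n1`) gives 40000 nM, the higher of the two numbers so far. Compound 2 (`COC(=O)c1ccc(CN(CCCc2c(N)nc(N)nc2O)c2cc(F)c([N+](=O)[O-])cc2[N+](=O)[O-])cc1`) gives 2500 nM. Among the compounds with values here, the only measured step is a 16-fold lower number from compound 1 to compound 2 (1.20 log units; beyond the scatter), which is large and beyond the scatter, and it comes with methoxycarbonyl in place of (1,3-dicarboxypropyl)amino on an aromatic carbon. Compound 3 (`Nc1nc(N)c(CCCN(Cc2ccc(NC(CCC(=O)O)C(=O)O)cc2)c2cc(F)c(F)cc2[N+](=O)[O-])c(O)n1`) keeps that (1,3-dicarboxypropyl)amino group and changes another place: fluoro in place of nitro on an aromatic carbon. The fluoro that enters there is ortho to a fluoro group and meta to a nitro group. Within the data shown here, no measured step covers this change, so the one step available bears on it only weakly. In this assay, from the compounds shown here alone, no step beyond the scatter is therefore expected, and the direction stays open. The expected change is a 1.3-fold higher number from compound 1 to compound 3 (0.10 log units; within the scatter). For compound 3 the estimated value is 50000 nM, with an expected range of 15000 nM to 150000 nM.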

Compound 3, half-maximal inhibitory concentration: > 100000 nM
Compound 3: no number, only a limit (the forecaster's own chance of this, stated with the estimate: 25%); middle value at least 2.0-fold (0.30 log units) from the limit.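

In this assay, the nitro group at this place, para to a large group, cannot be exchanged for fluoro without a loss, and the change gives an at least 2.5-fold higher number from compound 1 to compound 3 (0.39 log units; beyond the scatter). Going by these compounds alone, compound 1 and compound 2 both carry this nitro group, so this step is the first reading on the position, and it points towards a weaker compound with the (1,3-dicarboxypropyl)amino group kept. Compound 3 gives > 100000 nM, which is a limit of the assay and not a number, so the full size of the step stays unknown: the limit of > 100000 nM in this assay, at which 1 of the 3 values shown sits.

From the compounds shown here alone, whether an amine or a nitrile at this place would read closer to nitro or to fluoro remains open. Also open, going by these compounds, is whether the same exchange would cost as much with methoxycarbonyl in place of the (1,3-dicarboxypropyl)amino group, as in compound 2.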